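The source may hold more compounds than are shown below. What is called first, only, known or untested is meant among the compounds shown, and "the series" means these compounds.

In an assay on isolated protein for inhibition of Indoleamine 2,3-dioxygenase 2 (Homo sapiens) (on this read-out lower numbers stand for stronger inhibition and higher numbers for weaker inhibition), three compounds have been measured so far:

compound 1 `OCc1cn(CCNc2nonc2/C(=N/O)Nc2ccc(F)c(Br)c2)nn1`: 794 nM
compound 2 `CCCCc1cn(CCNc2nonc2/C(=N/O)Nc2ccc(F)c(Br)c2)nn1`: 830 nM
compound 3 `OCCCCc1cn(CCNc2nonc2/C(=N/O)Nc2ccc(F)c(Br)c2)nn1`: 1080 nM

Compound 3 gives the highest of these three numbers, but its distance to compound 2 and to compound 1 lies within the scatter, so the three cannot be told apart. Compound 4 `CCC(C)(O)c1cn(CCNc2nonc2/C(=N/O)Nc2ccc(F)c(Br)c2)nn1` differs from compound 3 in one place: 1-hydroxy-1-methylpropyl in place of 4-hydroxybutyl on an aromatic carbon. For the measured compounds named here, the steps that bear on this are the ones that altered the same side chain: a 1.4-fold higher number from compound 1 to compound 3 (0.13 log units; within the scatter) and a 1.3-fold higher number from compound 2 to compound 3 (0.11 log units; within the scatter), both within the scatter, as is a 1.0-fold higher number from compound 1 to compound 2 (0.02 log units; within the scatter). Changes at this position have so far produced no step beyond the scatter, so a similar outcome is expected in this assay, namely a 1.1-fold lower number from compound 3 to compound 4 (0.06 log units; within the scatter). Compound 4 is therefore estimated at 950 nM, with a range from 450 nM to 2000 nM.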

Compound 4, half-maximal inhibitory concentration: 958 nM
Compound 4: middle estimate off by 1.0-fold (0.00 log units), on the low side, within the range that was stated.
By their numbers in this assay, from the lowest: compounds 1, 2, 4 and 3 (each within the scatter of the next).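

In this assay, rearranging the same atoms, 1-hydroxy-1-methylpropyl in place of 4-hydroxybutyl, gives a 1.1-fold lower number from compound 3 to compound 4 (0.05 log units; within the scatter). The new side chain also stays level with the butyl and hydroxymethyl groups, with a 1.2-fold higher number from compound 2 to compound 4 (0.06 log units; within the scatter) and a 1.2-fold higher number from compound 1 to compound 4 (0.08 log units; within the scatter), so all four compounds remain indistinguishable and this position has tolerated a branched chain as well as straight ones. Nothing measured here offers an explanation for this. As far as these compounds go, whether an amine, a carboxylic acid or a much longer chain at this position would produce a step beyond the scatter remains open.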